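A few compounds are considered here, and "the series" means these few. Any claim that something is new, unique, unknown or untested is made for them only; others in the source may bear on it.

Compound 1 `CC(C)c1ccnc(C(=O)Nc2nn[nH]n2)c1` was tested in a functional assay on the whole organism for inhibition, with Rattus norvegicus as the target, at a dose of 3 mg/kg by the oral route (on this read-out higher numbers stand for a stronger effect at the one dose given and lower numbers for a weaker effect), and in this read-out compound 1 gives 34%, the lowest of the three numbers recorded so far. Compound 3 `Cc1ccc(C)c(C(=O)Nc2nn[nH]n2)n1` gives 65%, a number beyond the scatter above compound 1. Compound 2 `CNc1ccc(-c2cc(C)cc(C(=O)Nc3nn[nH]n3)n2)cc1` gives 89%, further still above compound 1. Among the measured compounds shown here, none of these three compounds differs from another in a single place, so no step between measured compounds can be traced from them.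

Compound 4 `Cc1ccnc(C(=O)Nc2nn[nH]n2)c1` has not yet been measured. It differs from compound 1 in one place: methyl in place of isopropyl on an aromatic carbon. The two compounds share the rest of their structure, so whatever difference appears in this assay belongs to this single change. For the measured compounds named here, no measured pair shows a change of this kind, so the size of the step is open. A small step is expected, not clearly beyond the scatter, and on balance no strong movement in either direction. Compound 4 is expected to give 40%, with a range from 20% to 60%. This estimate implies an expected step of a number 6 percentage points higher from compound 1 to compound 4 (within the scatter).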

Compound 4, a percentage reported as inhibition, in the whole organism at one dose (the size of the read-out at that dose, not a potency): 42%
Beside the measured number, compound 4's estimate is 2 percentage points below it; the range from low to high includes it.
By their numbers in this assay, from the lowest: compounds 1 and 4 (each within the scatter of the next); then compound 3; then compound 2.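

Methyl in place of isopropyl gives a number 8 percentage points higher from compound 1 to compound 4 (within the scatter), the first single change on this shared core that can be traced in this assay. On an aromatic carbon opposite the ring nitrogen, this exchange of isopropyl for the smaller methyl therefore leaves the read-out at one dose within the usual scatter, so this one pair gives no sign that the read-out depends on which of these two groups sits there. Nothing available here bears on the reason for this result.

As far as these compounds go, whether an amine, a carboxylic acid or a longer chain at this same position would give a step beyond the scatter remains open. Also open, from the compounds shown here alone, is whether methyl in place of isopropyl would give a similar step at another position on the ring.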